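Urea aryl swap on the shared core: compound 4

This account rests on a few compounds, and the source may have more. Where it says the series, first, only, none or still open, it means among the compounds named here.

Compound 1 `COc1cc(Nc2ncnc3c(NC(=O)Nc4ccc(C)cc4C)cccc23)cc(OC)c1` is the weakest growth inhibitor of the three measured ureas in a functional assay on RT-112 cells (Homo sapiens) for antiproliferative activity, read by MTT assay, with a stated time of 72 h (a higher number here means a weaker inhibitor of growth, a lower number a stronger inhibitor of growth), where compound 1 gives 1290 nM. Compound 2 `COc1cc(Nc2ncnc3c(NC(=O)Nc4ccc(C)c(C)c4)cccc23)cc(OC)c1` gives 8.8 nM in this assay, and compound 3 `COc1cc(Nc2ncnc3c(NC(=O)Nc4cccc(C(F)(F)F)c4F)cccc23)cc(OC)c1` gives 471 nM. Both measured changes at the urea aryl group of compound 1 lowered the number: a 150-fold lower number from compound 1 to compound 2 (2.17 log units; beyond the scatter), and a 2.7-fold lower number from compound 1 to compound 3 (0.44 log units; beyond the scatter). Between the two alternatives, a 54-fold higher number from compound 2 to compound 3 (1.73 log units; beyond the scatter).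

Compound 4 `CCOC(=O)c1ccc(NC(=O)Nc2cccc3c(Nc4cc(OC)cc(OC)c4)ncnc23)cc1` is not yet measured. Relative to compound 1 the change is 4-(ethoxycarbonyl)phenyl in place of 2,4-dimethylphenyl on an amide-type nitrogen. Within the data shown here, no measured step leads to a 4-(ethoxycarbonyl)phenyl group, so the only bearing evidence is that every departure from 2,4-dimethylphenyl so far gave a lower number in this assay, once by a large margin and once by a modest one. A lower number beyond the scatter is therefore expected, closer to the modest step than to the large one, with wide uncertainty: an 11-fold lower number from compound 1 to compound 4 (1.03 log units; beyond the scatter). Compound 4 is estimated at 120 nM in this assay, within a range of 10 nM to 1500 nM.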

Compound 4, concentration for 50% growth inhibition: 317 nM
Compound 4: the middle estimate sits 2.6-fold (0.42 log units) below what was measured; low and high end bracket the measured number.
By their numbers in this assay, from the lowest: compound 2; then compounds 4 and 3 (each within the scatter of the next); then compound 1.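

In this assay, 4-(ethoxycarbonyl)phenyl on the amide-type nitrogen is a third replacement of 2,4-dimethylphenyl that lowers the number (a 4.1-fold lower number from compound 1 to compound 4 (0.61 log units; beyond the scatter)), and unlike the earlier groups it carries hydrogen-bond acceptors. That number cannot be separated from the one for 2-fluoro-3-(trifluoromethyl)phenyl (a 1.5-fold lower number from compound 3 to compound 4 (0.17 log units; within the scatter)), so these two quite different groups give the same reading here, and 3,4-dimethylphenyl remains well clear of the new group (a 36-fold higher number from compound 2 to compound 4 (1.56 log units; beyond the scatter)). Nothing at hand accounts for any of these steps.

On these data alone, it remains open whether the ethyl ester itself matters, which 4-carboxyphenyl or 4-(methoxycarbonyl)phenyl on the same nitrogen would test. As far as these compounds go, it is also open whether the result for compound 2 needs both methyl groups, which 3-methylphenyl and 4-methylphenyl would show.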